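The compounds below may be only part of what the source reports. "The series", "measured", "known", "first", "only" and "open" are said of these compounds alone.

Measured so far in a functional assay on A549 cells (Homo sapiens) for inhibition, read by sulforhodamine B assay, with a stated time of 72 h (a higher number here means a weaker inhibitor, a lower number a stronger inhibitor), are these three:
Compound 1 `CC1CN(C(=O)c2c(N)sc(-c3ccc(Cl)cc3)c2-c2ccc(Cl)cc2)CCN1` at 4930 nM
Compound 2 `Nc1sc(-c2ccc(Cl)cc2)c(-c2ccc(Cl)cc2)c1C(=O)NC1CCCCC1` at 2410 nM
Compound 3 `CC1CCN(C(=O)c2c(N)sc(-c3ccc(Cl)cc3)c2-c2ccc(Cl)cc2)CC1` at 1750 nM

With 1750 nM in hand, compound 3 stands at the low end of this small set: its nearest neighbour lies within the scatter (a 1.4-fold lower number from compound 2 to compound 3 (0.14 log units; within the scatter)) and its furthest beyond it (a 2.8-fold lower number from compound 1 to compound 3 (0.45 log units; beyond the scatter)). Compound 4 `Nc1sc(-c2ccc(Cl)cc2)c(-c2ccc(Cl)cc2)c1C(=O)Nc1ccccc1` has anilino in place of 4-methylpiperidin-1-yl on a carbonyl carbon. Going by the values given here, no measured compound carries anilino, so only the other exchanges at this carbonyl carbon can guide the estimate. Those away from 3-methylpiperazin-1-yl were modest (a 2.0-fold lower number from compound 1 to compound 2 (0.31 log units; beyond the scatter)), and the exchange of cyclohexylamino for 4-methylpiperidin-1-yl stayed within the scatter (a 1.4-fold lower number from compound 2 to compound 3 (0.14 log units; within the scatter)). Compound 4 keeps an amide hydrogen, as compound 2 does at 2410 nM in this series. No step beyond the scatter is therefore expected in this assay in either direction. The estimated change is small (a 1.4-fold higher number from compound 3 to compound 4 (0.15 log units; within the scatter)) and is expected to stay within the scatter. For compound 4 the estimated value is 2500 nM with an expected range from 1000 nM to 6000 nM in this measurement.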

Compound 4, half-maximal inhibitory concentration: 25000 nM
For compound 4 the middle estimate is 10-fold (1.00 log units) below the measured one; measured number above the stated range.
By their numbers in this assay, from the lowest: compounds 3 and 2 (each within the scatter of the next); then compound 1; then compound 4.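

At the carbonyl carbon, the exchanges among the earlier groups had stayed small, but in this assay anilino breaks that picture: in place of 4-methylpiperidin-1-yl it gives a large loss (a 14-fold higher number from compound 3 to compound 4 (1.15 log units; beyond the scatter)), and even in place of 3-methylpiperazin-1-yl it gives a clear one (a 5.1-fold higher number from compound 1 to compound 4 (0.71 log units; beyond the scatter)). Keeping the amide hydrogen therefore does not hold the level, since phenyl in place of cyclohexyl on an amide-type nitrogen also gives a large step (a 10-fold higher number from compound 2 to compound 4 (1.02 log units; beyond the scatter)). Nothing at hand explains this loss.

On these data alone, it remains open whether the loss follows the aromatic ring itself or its direct attachment to the amide nitrogen, which benzylamino would begin to separate. As far as these compounds go, it is equally open whether an anilino carrying a methoxy group or a chlorine on its ring would behave as anilino does here.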